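The source may report more compounds than this note shows. Statements on the series, on what has been measured and on what is new or still open speak of the compounds shown alone.

Notes on the series. Going by the values given here, in a functional assay on ECa-109 cells for inhibition, with ECa-109 cell line (Homo sapiens) as the target, read by sulforhodamine B assay (a lower number here means a stronger inhibitor, a higher number a weaker inhibitor), compound 2 `COc1cccc(NC2=CC(=O)c3nc4n(c3C2=O)[C@H]2OC[C@@H](O)[C@H]2OC4)c1` gives 7620 nM and compound 3 `CCc1ccc(NC2=CC(=O)c3nc4n(c3C2=O)[C@H]2OC[C@@H](O)[C@H]2OC4)cc1` gives 3080 nM; the step of a 2.5-fold lower number from compound 2 to compound 3 (0.39 log units; beyond the scatter) is the only single-point step measured. Compound 1 `CCCc1ccc(NC2=CC(=O)c3c(nc4n3[C@H]3OC[C@@H](O)[C@H]3OC4)C2=O)cc1` reports in this assay only a limit, > 4000 nM, and this limit (the limit of > 4000 nM in this assay, at which 1 of the 3 values shown sits) is where compound 1 stands. Compound 4 `Cc1ccc(NC2=CC(=O)c3c(nc4n3[C@H]3OC[C@@H](O)[C@H]3OC4)C2=O)cc1` differs from compound 1 by hydrogen in place of ethyl on a saturated chain carbon bound to an aromatic carbon. Among the compounds with values here, no measured step bears directly on this change; compound 3 carries the 4-ethylphenyl group and compound 1 the 4-propylphenyl group, and nothing here separates a shorter from a longer chain beyond the scatter. A step of no meaningful size is therefore expected, a number no higher from compound 1 to compound 4 (the limit leaves the size open). Compound 4 is expected to give 4000 nM in this assay, within 1500 nM to 12000 nM.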

Compound 4, half-maximal inhibitory concentration: > 4000 nM
Compound 4: a limit, no number; the forecaster's own chance of this, stated with the estimate: 40%; the middle value lies on the limit itself.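

Compound 1 and compound 4 each report only a limit in this assay, so no step between them can be read: the limit of > 4000 nM in this assay, at which 2 of the 4 values shown sit.

On these data alone, whether 4-methylphenyl in place of 4-propylphenyl shifts the number at all remains open.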